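The source may report more compounds than this note shows. Statements on the series, on what has been measured and on what is new or still open speak of the compounds shown alone.

In a functional assay on HT-29 cells (Homo sapiens) for inhibition, read by luminescence and CellTiter-Glo, with a stated time of 24 h (a higher number here means that more compound is needed for the effect, a lower number that less compound is needed), three compounds built on one shared core have been measured. Compound 1 `CCCCCn1nc(C(=O)N[C@H]2COc3ccccc3N(C)C2=S)nc1Cc1ccccc1` gives 805 nM. Compound 2 `CC(C)n1nc(C(=O)N[C@H]2COc3ccccc3N(C)C2=S)nc1Cc1ccccc1` gives 360 nM, the lowest of the three numbers. Compound 3 `CN1C(=S)[C@@H](NC(=O)c2nc(Cc3ccccc3)n(CCCCC#N)n2)COc2ccccc21` gives 2680 nM. The step of a 2.2-fold lower number from compound 1 to compound 2 (0.35 log units; beyond the scatter) shows that isopropyl in place of pentyl on the aromatic nitrogen brings a lower number, while the step of a 7.4-fold higher number from compound 2 to compound 3 (0.87 log units; beyond the scatter) shows that 4-cyanobutyl in place of isopropyl brings a higher one, and a 3.3-fold higher number from compound 1 to compound 3 (0.52 log units; beyond the scatter) points the same way. Compound 4 `CN1C(=S)[C@@H](NC(=O)c2nc(Cc3ccccc3)n(C3CCCCCC3)n2)COc2ccccc21` differs from compound 2 by a single change: cycloheptyl in place of isopropyl on an aromatic nitrogen. Both measured steps away from compound 2 replaced isopropyl with a larger group and raised the number, yet the entering cycloheptyl is a carbon ring with no nitrile, so neither step matches it closely. A modestly higher number than compound 2 is therefore expected for compound 4 in this assay, with the step of a 1.8-fold higher number from compound 2 to compound 4 (0.26 log units; within the scatter) expected to stay small. Compound 4 is estimated at 650 nM, with a range from 250 nM to 1700 nM.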

Compound 4, half-maximal effective concentration: 5530 nM
Compound 4: middle estimate off by 8.5-fold (0.93 log units), on the low side; the measured number lies above the stated range.
By their numbers in this assay, from the lowest: compound 2; then compound 1; then compound 3; then compound 4.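

In this assay, cycloheptyl in place of isopropyl on the aromatic nitrogen gives a 15-fold higher number from compound 2 to compound 4 (1.19 log units; beyond the scatter), the largest step among the four compounds at this position. The carbon ring, which carries no nitrile, also ends above both chains, with a 2.1-fold higher number from compound 3 to compound 4 (0.31 log units; beyond the scatter) and a 6.9-fold higher number from compound 1 to compound 4 (0.84 log units; beyond the scatter), so a nitrile is not needed for a high number here. No measurement at hand gives a reason for this rise.

The compounds shown leave open whether a smaller carbon ring such as cyclopentyl would read close to compound 2 or close to compound 4. They also leave open how a chain ending in an amine or a carboxylic acid would read on this nitrogen.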